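Compound 2 to compound 4: a step at the limit

The source may report more compounds than this note shows. Statements on the series, on what has been measured and on what is new or still open speak of the compounds shown alone.

Measured in a physicochemical assay for pharmacokinetics, at pH 6; a higher number here means that the compound lasts longer, a lower number that the compound disappears faster:
- compound 1 `O=C(O)CCn1c(=O)oc2cc(OCC3CC3)c(Cl)cc21`: > 1000 h as a limit of the assay
- compound 2 `Cc1ccc([C@@H](C)Oc2cc3onc(CCC(=O)O)c3cc2Cl)nn1`: > 1000 h as a limit of the assay
- compound 3 `CCOc1cc2oc(=O)n(CCC(=O)O)c2cc1Cl`: > 1000 h as a limit of the assay

Compound 2 has no number, only its limit of > 1000 h. The other two measured compounds also give only limits. The change to compound 4 (`C[C@@H](Oc1cc2onc(CCC(=O)O)c2cc1Cl)c1ccccn1`) is pyridin-2-yl in place of 6-methylpyridazin-3-yl on a saturated chain carbon bound to an oxygen on an aromatic ring and a saturated chain carbon.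

Among the compounds with values here, the one measured step in a single place, a step that the two limits leave unreadable from compound 1 to compound 3, concerns a different group and gives no size. The whole measured picture is the limit of > 1000 h in this assay, at which 3 of the 3 values shown sit. Within the data shown here, no measured step therefore sizes this change. The expectation rests on compound 2 with its limit of > 1000 h. In this assay no step beyond the usual scatter is expected, and a report at the same limit is the likely outcome for compound 4. The estimated step is a number no higher from compound 2 to compound 4 (the limit leaves the size open). Compound 4 is expected at 1000 h with an estimated range from 500 h to 2000 h.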

Compound 4, half-life: > 1000 h
Compound 4 ended at the assay's limit; the forecaster's own chance of this, stated with the estimate: 90%; the middle value sits exactly at the limit.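

No step can be read from compound 2 to compound 4, as both give only a limit in this assay: the limit of > 1000 h in this assay, at which 4 of the 4 values shown sit.

The compounds shown leave open the actual half-life of each compound, and whether pyridin-2-yl in place of 6-methylpyridazin-3-yl alters it at all in this assay.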